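Adding a Methoxy Group to Compound 2

The source may report more compounds than this note shows. Statements on the series, on what has been measured and on what is new or still open speak of the compounds shown alone.

Of the compounds shown here, two have so far been measured in a functional assay on MT4 cells (Homo sapiens); on this read-out lower numbers stand for stronger inhibition and higher numbers for weaker inhibition. Compound 1 `CC1=CC(=N)C(c2ccccc2)(c2ccccc2)O1` gives 26.5 ug/mL in this assay. Compound 2 `O=C1C=C(c2ccccc2)OC1` gives 31.7 ug/mL, the larger of the two numbers, but its nearest neighbour is compound 1 and the gap between them lies within the usual scatter, so the two values cannot be told apart. Compound 3 `COc1ccccc1C1=CC(=O)CO1` has not yet been measured. It differs from compound 2 in one place: methoxy in place of hydrogen on an aromatic carbon. Going by the values given here, no measured pair in this set differs in the same way, so the numbers themselves show nothing about what this change does. Compound 3 is therefore expected to give a number close to that of compound 2, with a step of a 1.1-fold lower number from compound 2 to compound 3 (0.02 log units; within the scatter) that stays within the scatter. The value of compound 3 in this assay is estimated at 30 ug/mL, with a range from 12 ug/mL to 75 ug/mL.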

Compound 3, concentration for 50% inhibition: 44.4 ug/mL
Compound 3: the middle estimate sits 1.5-fold (0.17 log units) below what was measured, and the stated range covers the measured number.
By their numbers in this assay, from the lowest: compounds 1, 2 and 3 (each within the scatter of the next).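

Going by these compounds alone, compound 3 and compound 2 form the first pair in this set that differs in one place, and in this assay methoxy in place of hydrogen on an aromatic carbon, ortho to a group of 6 heavy atoms, gives a 1.4-fold higher number from compound 2 to compound 3 (0.15 log units; within the scatter). This position of the six-membered aromatic ring therefore takes methoxy, with its 2 heavy atoms, without any difference that this read-out can separate from the scatter. Nothing available bears on why the result falls as it does.

The compounds shown leave open whether an amine, a carboxylic acid or a longer chain such as ethoxy at this position would shift the number beyond the scatter. They also leave open whether methoxy on another carbon of the same ring would behave as it does here.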